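The compounds below may be only part of what the source reports. "The series", "measured", "known", "first", "only" and "open" are said of these compounds alone.

Measured compounds in the series:

compound 1, `CCN(CC)CCNC(=O)c1ccc(C(CC)(CC)c2ccc(OCC(=O)C(C)(C)C)c(C)c2)n1CC`, which in an ADME assay on L02 cells (Homo sapiens) for cytotoxicity, read by MTT assay, with a stated time of 48 h (a lower number here means a stronger inhibitor, a higher number a weaker inhibitor), gives 2500 nM
compound 2, `CCN(CC)CCCNC(=O)c1ccc(C(CC)(CC)c2ccc(OCC(=O)C(C)(C)C)c(C)c2)n1CC`, which in this assay gives 2300 nM
compound 3, `C#CCNC(=O)c1ccc(C(CC)(CC)c2ccc(OCC(O)C(C)(C)C)c(C)c2)n1CC`, which in this assay gives 4400 nM

Compound 3 sits at the high end of the three numbers, but its gap to compound 1, the nearest, and to compound 2, the furthest, each stay within the scatter, so the three measured compounds are not separated in this assay.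

Compound 4 is `CCn1c(C(=O)OCc2ccc(F)cc2)ccc1C(CC)(CC)c1ccc(OCC(O)C(C)(C)C)c(C)c1`, not yet measured. It departs from compound 3 as follows: (4-fluorobenzyl)oxy in place of propargylamino on a carbonyl carbon. Among the measured compounds shown here, only one measured step exists, a 1.1-fold lower number from compound 1 to compound 2 (0.04 log units; within the scatter), and it touches a different part of the molecule: the amide was kept in both compound 1 and compound 2, and only the chain on its nitrogen was lengthened. For the measured compounds named here, no measured pair swaps the amide for an ester, so nothing in hand speaks directly to (4-fluorobenzyl)oxy in place of propargylamino on a carbonyl carbon. Going by the values given here, the one step seen was within the scatter; by default no step beyond the scatter is expected, and the range is kept wide to reflect the lack of a bearing comparison.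

Compound 4 is therefore expected to give about 4000 nM in this assay, within 1500 nM to 12000 nM, an expected step of a 1.1-fold lower number from compound 3 to compound 4 (0.04 log units; within the scatter).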

Compound 4, half-maximal inhibitory concentration: 14900 nM
For compound 4 the middle estimate is 3.7-fold (0.57 log units) below the measured one; measured number above the stated range.
By their numbers in this assay, from the lowest: compounds 2, 1 and 3 (each within the scatter of the next); then compound 4.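

In this assay, replacing propargylamino with (4-fluorobenzyl)oxy on a carbonyl carbon gives a 3.4-fold higher number from compound 3 to compound 4 (0.53 log units; beyond the scatter), the first listed step in the series to lie beyond the scatter. The earlier step, a 1.1-fold lower number from compound 1 to compound 2 (0.04 log units; within the scatter), only lengthened the chain on the amide nitrogen, so this carbonyl substituent is the first place shown where a structural change separates two compounds. The swap is a single change on paper but alters several things together, replacing the amide nitrogen and its hydrogen-bond donor with an oxygen link, a six-membered aromatic ring and a fluorine, and no measurement here assigns the shift to any one of these.

Still open, as far as these compounds go, is whether a 4-fluorobenzyl amide on the same carbonyl carbon would read with compound 3 or with compound 4, and where a methyl ester or the free carboxylic acid would fall. The ketone and alcohol forms of the side chain also remain unresolved, as compound 3 differs from compound 1 and compound 2 in more than one place.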